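This account rests on a few compounds, and the source may have more. Where it says the series, first, only, none or still open, it means among the compounds named here.

Series notes. In a physicochemical assay for lipophilicity, read by HPLC, at pH 7.5 (a lower number here means a more polar compound, a higher number a more lipophilic compound), compound 1 `CC[C@@H](Nc1c(C#N)c(-c2ccc(-c3ccccc3CO)cc2)nc2cnccc12)C(N)=O` gives 2.1. Compound 3 `CCOc1ccccc1-c1ccc(-c2nc3cnccc3c(NC(C)C(=O)O)c2C#N)cc1` gives 2.1 in this assay, so compound 1 stands level with compound 3 at the digits shown, the two together the lowest of the three numbers. Compound 2 `CCOc1ccccc1-c1ccc(-c2nc3cnccc3c(N[C@H](CC)C(=O)NS(=O)(=O)C3CC3)c2C#N)cc1` gives 2.3 in this assay, the furthest from compound 1, yet still within the scatter. Among the compounds with values here, the only measured step, a number 0.20 log units lower from compound 2 to compound 3 (within the scatter), sits on a nitrogen on an aromatic ring, a different place from the one changed here. Compound 4 `CC[C@@H](Nc1c(C#N)c(-c2ccc(-c3cnccc3C)cc2)nc2cnccc12)C(N)=O` differs from compound 1 by 4-methylpyridin-3-yl in place of 2-(hydroxymethyl)phenyl on an aromatic carbon. Within the data shown here, no measured step bears on this exchange, so the expectation rests on the structural change alone. The step of a number 0.20 log units lower from compound 1 to compound 4 (within the scatter) is expected to stay within the scatter. Compound 4 is estimated at 1.9, between 1.4 and 2.4.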

Compound 4, distribution coefficient: 2
Beside the measured number, compound 4's estimate is 0.10 log units below it; the range from low to high includes it.
By their numbers in this assay, from the lowest: compounds 4, 1, 3 and 2 (each within the scatter of the next).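

In this assay, within the data shown here, 4-methylpyridin-3-yl in place of 2-(hydroxymethyl)phenyl on an aromatic carbon gives a number 0.10 log units lower from compound 1 to compound 4 (within the scatter), the only measured step at this position. The hydrogen-bond donor of 2-(hydroxymethyl)phenyl is absent from 4-methylpyridin-3-yl, yet the printed values do not separate the two compounds. Nothing available accounts for this result. Still open, from the compounds shown here alone, is how this assay would read with a ring carrying an amine or a carboxylic acid at this aromatic carbon. Also open, going by these compounds, is whether a longer chain in place of the methyl would stay within the scatter.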